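From propylsulfanyl to cyclohexylamino: notes on tolerated concentration

This account rests on a few compounds, and the source may have more. Where it says the series, first, only, none or still open, it means among the compounds named here.

- compound 1 `Nc1nc(OCc2ccccc2)c2ncn(/C=C3/CC3(CO)CO)c2n1`: > 20000 nM (a limit)
- compound 2 `CCCSc1nc(N)nc2c1ncn2/C=C1/CC1(CO)CO`: 98000 nM
- compound 3 `Nc1nc2c(ncn2/C=C2/CC2(CO)CO)c(=O)[nH]1`: > 20000 nM (a limit)
- compound 4 `Nc1nc(NC2CCCCC2)c2ncn(/C=C3/CC3(CO)CO)c2n1`: not yet measured

The read-out is an ADME assay on CCRF-HSB-2 cells (Homo sapiens) for cytotoxicity, with a stated time of 7 days; a higher number here means that more compound is tolerated, a lower number that less compound is tolerated. Going by the values given here, compound 2 gives 98000 nM, the only actual number. Compound 1 gives > 20000 nM, which is a limit. Compound 3 gives > 20000 nM, which is also a limit.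

The next change is cyclohexylamino in place of propylsulfanyl on an aromatic carbon, (cyclohexylamino in place of propylsulfanyl on an aromatic carbon).

Among the compounds with values here, only one measured step bears on this position: a step that the limit leaves unreadable from compound 1 to compound 2, with propylsulfanyl in place of benzyloxy. Going by these compounds, its size stays unknown because of the limit of > 20000 nM in this assay, at which 2 of the 3 values shown sit. The series therefore offers no measured size for a change at this carbon. On these data alone, with compound 2 at 98000 nM as the anchor, no step beyond the usual scatter is expected in this assay, and the direction remains open. The estimated change is a 1.8-fold lower number from compound 2 to compound 4 (0.25 log units; within the scatter). A limit instead of a number is also quite possible. For compound 4 the expected value is 55000 nM, with an estimated range of 15000 nM to 150000 nM.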

Compound 4, half-maximal cytotoxic concentration: > 20000 nM
Compound 4: no number, only a limit (the forecaster's own chance of this, stated with the estimate: 60%); the middle value lies beyond the limit too.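

In this assay compound 4 gives > 20000 nM as a limit and not a number. Its steps from compound 1 and compound 2 cannot be read: the limit of > 20000 nM in this assay, at which 3 of the 4 values shown sit.

The compounds shown leave open how cyclohexylamino, benzyloxy and propylsulfanyl compare at this aromatic carbon.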